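The source may hold more compounds than are shown below. What is called first, only, known or untested is meant among the compounds shown, and "the series" means these compounds.

Measured compounds:
compound 1 `COc1cc2c(Oc3ccc(NC(=O)c4nnn(-c5ccccc5C(F)(F)F)c4C)cc3F)ccnc2cc1OCCCN1CCCC1` gives 230 nM in a functional assay on NCI-H460 cells (Homo sapiens) for cytotoxicity, read by MTT assay, with a stated time of 72 h; on this read-out higher numbers stand for weaker inhibition and lower numbers for stronger inhibition
compound 2 `COc1cc2c(Oc3ccc(NC(=O)c4nnn(-c5ccc(F)cc5)c4C(F)(F)F)cc3F)ccnc2cc1OCCCN1CCCC1` gives 150 nM in this assay
compound 3 `COc1cc2c(Oc3ccc(NC(=O)c4nnn(-c5ccc(C)cc5)c4C(F)(F)F)cc3F)ccnc2cc1OCCCN1CCCC1` gives 790 nM in this assay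

Compound 3 stands at the highest number of the three, beyond the scatter from both compound 1 and compound 2. For the measured compounds named here, the only single-point step among the measured compounds is a 5.3-fold higher number from compound 2 to compound 3 (0.72 log units; beyond the scatter), so an exchange of the group on the aromatic nitrogen of the five-membered ring has already moved the read-out well beyond the scatter within this set.

Compound 4 `COc1cc2c(Oc3ccc(NC(=O)c4nnn(-c5ccccc5C(F)(F)F)c4C(F)(F)F)cc3F)ccnc2cc1OCCCN1CCCC1` is the next member. The change from compound 3 is 2-(trifluoromethyl)phenyl in place of 4-methylphenyl on an aromatic nitrogen. Compound 1 also carries 2-(trifluoromethyl)phenyl on the aromatic nitrogen and gives 230 nM, a number close to that of compound 2 rather than to compound 3. Going by the values given here, only one step bears directly on the exchange, and it points to the group on the aromatic nitrogen as the place where the numbers spread. Because compound 3 sits at 790 nM while compound 1 sits at 230 nM, the expectation for compound 4 is a lower number, with an estimated step of a 3.6-fold lower number from compound 3 to compound 4 (0.56 log units; beyond the scatter). Compound 4 is therefore estimated at 220 nM in this assay, with a range from 80 nM to 600 nM.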

Compound 4, half-maximal inhibitory concentration: 270 nM
The estimate for compound 4 lay 1.2-fold (0.09 log units) below the measured number; low and high end bracket the measured number.
By their numbers in this assay, from the lowest: compounds 2, 1 and 4 (each within the scatter of the next); then compound 3.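

In this assay, with trifluoromethyl held on the ring carbon, the exchange at the aromatic nitrogen of 4-methylphenyl for 2-(trifluoromethyl)phenyl gives a 2.9-fold lower number from compound 3 to compound 4 (0.47 log units; beyond the scatter) and the exchange of 4-fluorophenyl for 2-(trifluoromethyl)phenyl gives a 1.8-fold higher number from compound 2 to compound 4 (0.26 log units; within the scatter) so among these three groups on the nitrogen only 4-methylphenyl stands apart, while 4-fluorophenyl and 2-(trifluoromethyl)phenyl cannot be told apart. For the compounds shown here, the ring carbon can now be read for the first time: with 2-(trifluoromethyl)phenyl on the nitrogen, trifluoromethyl in place of methyl gives a 1.2-fold higher number from compound 1 to compound 4 (0.07 log units; within the scatter) and this single pair therefore shows no separable change from that exchange, leaving the spread in this set at the nitrogen rather than at the carbon. No measurement at hand accounts for these steps.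

Going by these compounds, whether the carbon exchange stays this flat with 4-fluorophenyl or 4-methylphenyl on the nitrogen remains open. Also open, on these data alone, is how the read-out responds to a phenyl ring carrying a methoxy group or a nitrile, or to a longer alkyl chain in place of the phenyl ring on the nitrogen.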